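The source may report more compounds than this note shows. Statements on the series, on what has been measured and on what is new or still open speak of the compounds shown alone.

Three compounds have been measured:
compound 1, `CNC(=S)N/N=C/c1ncc(F)c2ccccc12`, 2080 nM;
compound 2, `CNC(=S)NN=Cc1nccc2c(NC)cccc12`, 4240 nM;
compound 3, `NC(=S)N/N=C/c1ncc(F)c2ccccc12`, 24600 nM.

These values come from a functional assay on MIA PaCa-2 cells (Homo sapiens) for cytotoxicity, read by luminescence, with a stated time of 72 h; a higher number here means a weaker inhibitor, a lower number a stronger inhibitor. Compound 1 and compound 3 share a core and differ in one place: hydrogen in place of methyl on an amide-type nitrogen. This change gives a 12-fold higher number from compound 1 to compound 3 (1.07 log units; beyond the scatter), a large loss. Compound 2 has a different core; the difference between the two cores is not broken down here. Among the three values compound 2 stands second highest, with compound 1 nearest and compound 3 furthest.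

Compound 4, `CNC(=S)NN=Cc1nccc2c(N)cccc12`, has not yet been measured. It differs from compound 2 in one place: hydrogen in place of methyl on a nitrogen on an aromatic ring. Among the compounds with values here, this is the same kind of change as the one from compound 1 to compound 3, but at a different place: there the nitrogen is an amide-type nitrogen whose other neighbours are thiocarbonyl carbon, here it is a nitrogen on an aromatic ring whose other neighbours are aromatic carbon. Within the data shown here, only one measured pair shows such a change, and at another place, so the large loss seen there need not carry over. Compound 4 is expected to give 7500 nM in this assay, with a likely range from 2500 nM to 25000 nM. Compound 4 is thus estimated to show a modest step, a 1.8-fold higher number from compound 2 to compound 4 (0.25 log units; within the scatter). That would be smaller than the step measured from compound 1 to compound 3.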

Compound 4, concentration for 90% inhibition: 11200 nM
Beside the measured number, compound 4's estimate is 1.5-fold (0.17 log units) below it, and the stated range covers the measured number.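

Replacing methyl with hydrogen gives a higher number, meaning a weaker inhibitor, in both measured pairs; in this assay, the methylamino to amino change gives a 2.6-fold higher number from compound 2 to compound 4 (0.42 log units; beyond the scatter). The direction is shared, but the size of the step does not carry over from one core to the other: the same change on two cores in this assay, a 12-fold higher number (1.07 log units; beyond the scatter) from compound 1 to compound 3 and a 2.6-fold higher number (0.42 log units; beyond the scatter) from compound 2 to compound 4, 4.5-fold (0.65 log units) apart, beyond the scatter of two such steps. This does not show what sets the size, as the two pairs differ in place as well as in core, one change being on an amide-type nitrogen and the other on a nitrogen on an aromatic ring, and two pairs cannot separate these or set a rule for the series.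

The compounds shown leave open how a longer chain, such as ethyl, or an acetyl group would compare with methyl on the nitrogen on the aromatic ring. Also open, from the compounds shown here alone, is what step hydrogen in place of methyl on the amide-type nitrogen would give on the core of compound 2, which would test place and core apart.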